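The source may report more compounds than this note shows. Statements on the series, on what has been measured and on what is new or still open speak of the compounds shown alone.

Compound 1 `COC(C)CO[C@H](CC=C(C)C)C1=CC(=O)c2c(O)ccc(O)c2C1=O` gives 16600 nM in a functional assay on DU-145 cells (Homo sapiens) for cytotoxicity, read by MTT assay; a lower number here means a stronger inhibitor, a higher number a weaker inhibitor. Compound 2 `CC(=O)OCCO[C@H](CC=C(C)C)C1=CC(=O)c2c(O)ccc(O)c2C1=O` gives 15500 nM in the same test.

Compound 2 does not stand apart from compound 1: a 1.1-fold lower number from compound 1 to compound 2 (0.03 log units; within the scatter), so the two numbers are indistinguishable. The next compound, compound 3 `CCC(C)(O)CC(=O)O[C@H](CC=C(C)C)C1=CC(=O)c2c(O)ccc(O)c2C1=O`, carries a further change at the same oxygen: (2-hydroxy-2-methylbutyl)carbonyl in place of 2-acetoxyethyl on an oxygen on a saturated carbon. Within the data shown here, the only measured step that bears on this place is the one from compound 1 to compound 2, and it was within the scatter, so the side chain beyond that oxygen appears to matter little here. Compound 3 is therefore expected to show a 1.1-fold lower number from compound 2 to compound 3 (0.04 log units; within the scatter), a step not beyond the scatter. The estimate for compound 3 is 14000 nM, ranging from 5000 nM to 40000 nM.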

Compound 3, half-maximal inhibitory concentration: 16000 nM
The estimate for compound 3 lay 1.1-fold (0.06 log units) below the measured number; the measured number falls inside the stated range.
By their numbers in this assay, from the lowest: compounds 2, 3 and 1 (each within the scatter of the next).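

In this assay, the swap to (2-hydroxy-2-methylbutyl)carbonyl, which brings a hydrogen-bond donor that 2-acetoxyethyl lacks, gives a 1.0-fold higher number from compound 2 to compound 3 (0.01 log units; within the scatter) and a 1.0-fold lower number from compound 1 to compound 3 (0.02 log units; within the scatter) as its two steps. The earlier compounds shown here showed only that two ether-linked side chains match; a carbonyl placed directly on this oxygen also leaves the number within the scatter. No evidence at hand accounts for this.

On these data alone, whether an amine or a carboxylic acid in this side chain would move the number stays open, as does the effect of any change to the shared core.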